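Adding a Second Chloro to the Purine Core of Compound 2

The source may hold more compounds than are shown below. What is called first, only, known or untested is meant among the compounds shown, and "the series" means these compounds.

This account follows a small series of purine-based compounds built for cell growth inhibition, read in a functional assay on SF-539 cells (Homo sapiens) for cytotoxicity, read by sulforhodamine B assay, with a stated time of 48 h; a higher number here means a weaker inhibitor of growth, a lower number a stronger inhibitor of growth. Compound 1, `ClCc1cccc(Cn2cnc3nc(Cl)nc(Cl)c32)c1`, carries two chloro groups on its bicyclic core and a chloromethyl-benzyl arm; in this assay compound 1 gives 460 nM. Compound 2, `ClCc1ccc(Cn2cnc3ncnc(Cl)c32)cc1`, keeps a single chloro on the core and places the chloromethyl group elsewhere on the benzyl ring; in this assay compound 2 gives 3710 nM. Compound 2 thus stands at the higher of the two numbers recorded, and its gap to compound 1 lies well beyond the usual scatter.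

Compound 3, `ClCc1ccc(Cn2cnc3nc(Cl)nc(Cl)c32)cc1`, is the not yet measured partner of compound 2. The change from compound 2 to compound 3 is chloro in place of hydrogen on an aromatic carbon. For the measured compounds named here, no measured pair in this set isolates that single change, so no step value can be quoted for it.

The expectation for compound 3 in this assay is nevertheless a lower number than compound 2, because compound 1 , which also carries the chloro between the two ring nitrogens, gives 460 nM. The step from compound 2 to compound 3 is expected to be a 4.6-fold lower number from compound 2 to compound 3 (0.67 log units; beyond the scatter), a drop beyond the scatter. Compound 3 is estimated at 800 nM in this assay, with a plausible range from 300 nM to 2500 nM.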

Compound 3, concentration for total growth inhibition: 3310 nM
Estimate against measurement, compound 3: 4.1-fold (0.62 log units) below; the whole stated range lies below it.
By their numbers in this assay, from the lowest: compound 1; then compounds 3 and 2 (each within the scatter of the next).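

In this assay the step is a 1.1-fold lower number from compound 2 to compound 3 (0.05 log units; within the scatter) for chloro in place of hydrogen on the aromatic carbon between two ring nitrogen atoms, so with the chloromethyl group placed as in compound 2, this change leaves the number within the scatter. Compound 3 carries the same chloro as compound 1 and differs from it only in where the chloromethyl group sits on the benzyl ring, yet compound 3 gives 3310 nM and compound 1 gives 460 nM in this assay, so the chloro alone does not bring a number like that of compound 1. Nothing in the data shown accounts for how little this change does here.

Going by these compounds, what stays open is whether this position responds to other groups in place of the chloro, such as an amine or a methoxy group. Also open is whether the same chloro would matter with the chloromethyl group placed as in compound 1, since the partner of compound 1 with hydrogen at this position is not among the compounds shown.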